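Shortening the butyl chain of compound 2 to propyl

This account rests on a few compounds, and the source may have more. Where it says the series, first, only, none or still open, it means among the compounds named here.

In a physicochemical assay for acid dissociation, at 37 degrees C, compound 1 `CCCCN(CCCC)Cc1cccnc1` gives 8.08 and compound 2 `CCCCNCc1cccnc1` gives 8.66, the higher of the two numbers. Compound 3 `CCCNCc1cccnc1` differs from compound 2 by hydrogen in place of methyl on a saturated chain carbon, three bonds along the chain from an amine nitrogen, or butyl to propyl. Going by the values given here, the only measured step, a number 0.58 log units higher from compound 1 to compound 2 (beyond the scatter), is modest and places hydrogen in place of butyl on an amine nitrogen, so it bears only loosely on this change. Among the compounds with values here, no measured step covers a change at this place. The expected step, a number 0.01 log units lower from compound 2 to compound 3 (within the scatter), stays within the scatter in this assay. For compound 3 the estimate is 8.65, with an expected range of 8.35 to 8.95.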

Compound 3, acid dissociation constant: 8.38
For compound 3 the middle estimate is 0.27 log units above the measured one; measured number inside the range.
By their numbers in this assay, from the lowest: compounds 1, 3 and 2 (each within the scatter of the next, the first and the last beyond it).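

In this assay butyl to propyl gives a number 0.28 log units lower from compound 2 to compound 3 (within the scatter) and so does not separate compound 3 from compound 2. Going by these compounds alone, this gives a first reading for a change on a saturated chain carbon, three bonds along the chain from an amine nitrogen, whereas the earlier step placed hydrogen in place of butyl on an amine nitrogen. No available evidence bears on this result.

From the compounds shown here alone, whether an ethyl or a methyl chain in place of propyl would give a step beyond the scatter stays open. The same holds for a longer chain such as pentyl.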